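Swapping methoxy for chloro on the aryl piperazine

The compounds below may be only part of what the source reports. "The series", "measured", "known", "first", "only" and "open" are said of these compounds alone.

Measured compounds:
compound 1 `CCC1(CCCCN2CCN(c3ccc(Cl)cc3)CC2)C(=O)Nc2cc(F)ccc21` gives 215 nM
compound 2 `CCC1(CCCCN2CCN(c3ccccc3OC)CC2)C(=O)Nc2ccccc21` gives 27 nM

Both values come from an assay on membranes from frontal cortex for displacement of a labelled ligand from Adrenergic receptor alpha-1 (Rattus norvegicus), read by scintillation counting, with a stated time of 45 min; on this read-out higher numbers stand for weaker inhibition and lower numbers for stronger inhibition. Among the two numbers, compound 2 has the lower one, and the gap to compound 1 is beyond the usual scatter, so compound 2 is the stronger inhibitor of the pair. The two compounds differ in more than one place, so their values show only that the combination of substituents in compound 2 is the more favourable one.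

Compound 3 `CCC1(CCCCN2CCN(c3ccccc3Cl)CC2)C(=O)Nc2ccccc21` has not yet been measured. It differs from compound 2 in one place: chloro in place of methoxy on an aromatic carbon. Within the data shown here, no measured pair in this set isolates that exchange, so its effect cannot be read from the numbers at hand. The expectation is a modest weakening, a step of a 2.0-fold higher number from compound 2 to compound 3 (0.31 log units; beyond the scatter), which would still leave compound 3 well inside the range of the two measured compounds. On that basis compound 3 is estimated at 55 nM in this assay, with a range from 20 nM to 150 nM.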

Compound 3, inhibition constant: 64 nM
Compound 3: middle estimate off by 1.2-fold (0.07 log units), on the low side, and the stated range covers the measured number.
By their numbers in this assay, from the lowest: compound 2; then compound 3; then compound 1.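

In this assay, the exchange of methoxy for chloro on an aromatic carbon ortho to a large group is now isolated in a single pair, and the 2-methoxyphenyl to 2-chlorophenyl change gives a 2.4-fold higher number from compound 2 to compound 3 (0.37 log units; beyond the scatter) in a step that is modest but beyond the scatter. The position therefore responds to this exchange without losing inhibition: compound 3 still gives 64 nM with chloro, which counts no hydrogen-bond acceptor and one heavy atom, in place of methoxy, which counts one hydrogen-bond acceptor and two heavy atoms. Nothing available explains why the step has this direction or size.

Among these compounds, this single pair defines the effect of only one exchange at one position on one core, so it cannot show whether the same step would appear with the other substituents found. On these data alone, how an ethoxy group, a hydroxyl group or an amine would behave at this position remains open, and so does whether the chloro or methoxy group would give a similar step elsewhere on the aromatic ring.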